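Aryl swap on the oxazole: cytotoxicity outlook for compound 3

The compounds below may be only part of what the source reports. "The series", "measured", "known", "first", "only" and "open" are said of these compounds alone.

Of the compounds shown here, two have been read in an ADME assay on Huh7.5.1 cells (Homo sapiens) for cytotoxicity, read by ATP content, with a stated time of 48 h; a higher number here means that more compound is tolerated, a lower number that less compound is tolerated. Compound 1 `Cc1oc(-c2c(Cl)cccc2Cl)nc1CN1CCC(C(=O)NCCCN2C[C@H](C)C[C@H](C)C2)CC1` gives 13200 nM, and compound 2 `Cc1ccccc1-c1nc(CN2CCC(C(=O)NCCCN3[C@H](C)CCC[C@@H]3C)CC2)c(C)o1` gives 21300 nM. The gap between compound 1 and compound 2 lies within the scatter of repeated measurements, so the two stand together and neither can be said to be tolerated better than the other; compound 1 simply marks the smaller of the two numbers shown, with compound 2 close by.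

Compound 3 `Cc1ccc(-c2nc(CN3CCC(C(=O)NCCCN4C[C@H](C)C[C@H](C)C4)CC3)c(C)o2)cc1` is not yet measured in this assay. It differs from compound 1 in one place: 4-methylphenyl in place of 2,6-dichlorophenyl on an aromatic carbon. Among the compounds with values here, no measured pair isolates this change, so nothing here gives its size directly. Both measured compounds carry a different substituted phenyl on the shared core and still land close together, which argues for a small step.

For compound 3 the expected step of a 1.1-fold higher number from compound 1 to compound 3 (0.06 log units; within the scatter) is none beyond the scatter, with the number estimated at 15000 nM, in a range from 7000 nM to 32000 nM.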

Compound 3, half-maximal cytotoxic concentration: 4330 nM
For compound 3 the middle estimate is 3.5-fold (0.54 log units) above the measured one; measured number outside the range, below it.
By their numbers in this assay, from the lowest: compound 3; then compounds 1 and 2 (each within the scatter of the next).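

In this assay, the aryl group on the aromatic carbon next to the ring nitrogen and next to the ring oxygen proves able to move the read-out: 4-methylphenyl in place of 2,6-dichlorophenyl gives a 3.0-fold lower number from compound 1 to compound 3 (0.48 log units; beyond the scatter), a modest step and the only one shown that isolates this position. The closeness of compounds 1 and 2 therefore cannot be taken as a sign that the aryl group is of no consequence, since those two compounds differ in more than one place. Nothing available accounts for the direction or size of this step.

This single swap removes two chlorine atoms and adds a methyl group in one move, so the compounds shown do not separate the contribution of either change, or say whether the substituent's place on the phenyl ring matters. Going by these compounds, a plain phenyl group on the core of compound 1 would give a common reference for both substituted rings, and it remains open whether the same step would appear with the side chain of compound 2.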